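The source may report more compounds than this note shows. Statements on the series, on what has been measured and on what is new or still open speak of the compounds shown alone.

Measured so far in a functional assay on HeLa cells (Homo sapiens) for antiproliferative activity, read by CCK-8 assay, with a stated time of 72 h, tested at 8 uM; a higher number here means a stronger effect of the compound at the concentration tested, a lower number a weaker effect:
- compound 1 `Nc1ccccc1NC(=O)c1ccc(CSC(=S)N2CCN(Cc3ccccn3)CC2)cc1`: 61.4%
- compound 2 `CC1CCN(C(=S)SCc2ccc(C(=O)Nc3ccccc3N)cc2)CC1`: 72.5%

Compound 2 gives the highest of the two numbers, with compound 1 the nearest one, beyond the usual scatter. Compound 3 `CN(Cc1ccncc1)C(=S)SCc1ccc(C(=O)Nc2ccccc2N)cc1` is not yet measured. It differs from compound 2 in one place: methyl((pyridin-4-yl)methyl)amino in place of 4-methylpiperidin-1-yl on a thiocarbonyl carbon. Among the compounds with values here, no step between measured compounds covers this change, so the expectation rests on the two values alone. A drop of modest size is expected, near the edge of the scatter, shown as a number 10.5 percentage points lower from compound 2 to compound 3 (beyond the scatter). Compound 3 is estimated at 62%, within 46% to 78%.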

Compound 3, a percentage reported as inhibition, at one concentration (the size of the read-out at that concentration, not a potency): 72.7%
For compound 3 the middle estimate is 10.7 percentage points below the measured one, and the stated range covers the measured number.
By their numbers in this assay, from the lowest: compound 1; then compounds 2 and 3 (each within the scatter of the next).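

On the thiocarbonyl carbon in this assay, methyl((pyridin-4-yl)methyl)amino in place of 4-methylpiperidin-1-yl gives a number 0.2 percentage points higher from compound 2 to compound 3 (within the scatter). At this position and this concentration, a six-membered aromatic ring with 1 hetero atom thus serves as well as a six-membered non-aromatic ring, even with the larger group. Nothing on hand explains why the two groups read alike. Still open, as far as these compounds go, is whether morpholine or a carboxylic acid-bearing chain at this carbon would hold the read-out. A single concentration also leaves open whether compound 2 and compound 3 match in potency.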